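A few compounds are considered here, and "the series" means these few. Any claim that something is new, unique, unknown or untested is made for them only; others in the source may bear on it.

In a functional assay on L1210 cells (Mus musculus) for inhibition (on this read-out lower numbers stand for stronger inhibition and higher numbers for weaker inhibition), compound 1 `C#CCN(Cc1ccc2nc(C)nc(O)c2c1)c1ccccc1` gives > 6500 nM, which is a limit and not a number. Within the data shown here, compound 2 `C#CCN(Cc1ccc2nc(C)nc(O)c2c1)c1ccc(S(N)(=O)=O)cc1` gives 20000 nM, the only true number so far in this assay. Compound 3 `C#CCN(Cc1ccc2nc(C)nc(O)c2c1)c1ccc(S(=O)(=O)N2CCNCC2)cc1` carries piperazin-1-yl in place of amino on a sulfonyl sulfur. Among the measured compounds shown here, the only measured step is a step that the limit leaves unreadable from compound 1 to compound 2, so it offers no size to carry over, and the one reference it rests on is the limit of > 6500 nM in this assay, at which 1 of the 2 values shown sits. With no guide to size or direction, the expectation is no change beyond the scatter, an estimated no change at the digits printed from compound 2 to compound 3 (within the scatter). For compound 3 the expected value is 20000 nM, with an estimated range of 6000 nM to 60000 nM.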

Compound 3, half-maximal inhibitory concentration: > 50000 nM
Compound 3 gave a limit, no number; the forecaster's own chance of this, stated with the estimate: 35%; at least 2.5-fold (0.39 log units) between middle value and limit.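

Piperazin-1-yl in place of amino on a sulfonyl sulfur gives an at least 2.5-fold higher number from compound 2 to compound 3 (0.39 log units; beyond the scatter) in this assay, the first readable step here, and it points towards weaker inhibition. Going by these compounds, compound 3 gives > 50000 nM, which is a limit, so how far this step reaches stays unknown. The steps from compound 1 cannot be read, because that compound also stands at a limit: the limit of > 6500 nM in this assay, at which 1 of the 3 values shown sits.

Still open, on these data alone, is whether a smaller group on the sulfonyl sulfur, such as methylamino, would stay level with compound 2. As far as these compounds go, whether a morpholin-4-yl ring there would behave like piperazin-1-yl is equally open.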